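Aryl amines on a shared core against prostate cancer cells

The source may report more compounds than this note shows. Statements on the series, on what has been measured and on what is new or still open speak of the compounds shown alone.

Three compounds share one core and differ only in the group on a nitrogen on an aromatic ring. Compound 1 `CCCCCCCCNc1nc(SCc2ccc(C(F)(F)F)cc2)nc2ccccc12` carries an octyl chain there; in a functional assay on PC-3 cells (Homo sapiens) for cytotoxicity, read by MTT assay, with a stated time of 72 h (a lower number here means a stronger inhibitor, a higher number a weaker inhibitor), compound 1 gives 10500 nM, the lowest of the three numbers, though within the scatter of both others. Compound 2 `FC(F)(F)c1ccc(CSc2nc(Nc3cccc(C(F)(F)F)c3)c3ccccc3n2)cc1` carries 3-(trifluoromethyl)phenyl and gives 12900 nM; compound 3 `O=[N+]([O-])c1cccc(Nc2nc(SCc3ccc(C(F)(F)F)cc3)nc3ccccc23)c1` carries 3-nitrophenyl and gives 13500 nM. The steps are small: a 1.2-fold higher number from compound 1 to compound 2 (0.09 log units; within the scatter), a 1.3-fold higher number from compound 1 to compound 3 (0.11 log units; within the scatter), and a 1.0-fold higher number from compound 2 to compound 3 (0.02 log units; within the scatter), none of them beyond the scatter.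

Compound 4 `FC(F)(F)c1ccc(CSc2nc(Nc3ccc(Cl)cc3)c3ccccc3n2)cc1` has not yet been measured. It differs from compound 1 in one place: 4-chlorophenyl in place of octyl on a nitrogen on an aromatic ring. The two measured steps that bear on it, from compound 1 to compound 2 and from compound 1 to compound 3, both replace octyl with a substituted phenyl on the same nitrogen, and both stayed within the scatter. A change of the same kind is therefore expected to leave the number close to where compound 1 stands, perhaps slightly higher, as a 1.2-fold higher number from compound 1 to compound 4 (0.08 log units; within the scatter). Compound 4 is estimated at 12500 nM, with a range from 6000 nM to 26000 nM.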

Compound 4, half-maximal inhibitory concentration: 7110 nM
Estimate against measurement, compound 4: 1.8-fold (0.25 log units) above; low and high end bracket the measured number.
By their numbers in this assay, from the lowest: compounds 4, 1, 2 and 3 (each within the scatter of the next).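

Placing 4-chlorophenyl in place of octyl on a nitrogen on an aromatic ring gives a 1.5-fold lower number from compound 1 to compound 4 (0.17 log units; within the scatter) in this assay, so a third substituted phenyl group at this position also stays within the scatter of the octyl compound. The same holds among the substituted phenyl groups, with a 1.8-fold lower number from compound 2 to compound 4 (0.26 log units; within the scatter) and a 1.9-fold lower number from compound 3 to compound 4 (0.28 log units; within the scatter): although these are the widest steps in the set, 4-chlorophenyl cannot be told apart from 3-(trifluoromethyl)phenyl or 3-nitrophenyl, and across the four compounds neither the octyl chain nor any of the three substituted phenyl groups separates from its neighbours in the order of numbers. No measurement shown here offers an explanation for these numbers.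

What the compounds shown leave open is whether any group on this nitrogen can carry the number beyond the scatter, as an unsubstituted phenyl, a butyl chain, or a phenyl ring bearing a carboxylic acid or an amine might or might not do. They also leave open whether the same flat picture would hold if the group on the sulfur of the shared core were replaced.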